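This account rests on a few compounds, and the source may have more. Where it says the series, first, only, none or still open, it means among the compounds named here.

Compound 1 `CN(C)C(=O)c1cc(-c2cnc(NCc3c(F)ccc4c3CCO4)c3cn[nH]c(=O)c23)n(C)n1` gives 21 mL.min-1.g-1 in an ADME assay on microsomes from liver (Homo sapiens) for metabolic stability, read by LC-MS, using NADPH, with stated times of 5 min and 30 min, tested at 1 uM; on this read-out lower numbers stand for slow clearance and higher numbers for fast clearance.
Compound 2 `COCCC(=O)Nc1cnc(NCc2c(F)ccc3c2CCO3)n2cnnc12` gives < 3 mL.min-1.g-1 in this assay, which is a limit of the assay and not a number.
Compound 3 `C[C@H]1CC(=O)N(c2cnc(NCc3c(F)ccc4c3CCO4)n3cnnc23)C1` gives < 3 mL.min-1.g-1 in this assay, which likewise is a limit of the assay.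

Compound 1 stands as the only one of the three with a number of its own in this assay; the other two values sit at the limit of < 3 mL.min-1.g-1 in this assay, at which 2 of the 3 values shown sit. Compound 4 `Cc1ncc(-c2cnc(NCc3c(F)ccc4c3CCO4)c3cn[nH]c(=O)c23)n1C` is the unmeasured compound, and it differs from compound 1 in one place: 1,2-dimethyl-1H-imidazol-5-yl in place of 3-(dimethylcarbamoyl)-1-methyl-1H-pyrazol-5-yl on an aromatic carbon.

For the measured compounds named here, only one measured step exists between compounds differing in one place, the step from compound 2 to compound 3 in this assay, a step that the two limits leave unreadable from compound 2 to compound 3. Both of those compounds carry a different core from compound 1 and compound 4, and since both values are limits, the size of that step cannot be read, so it offers no guide to the present change. Going by the values given here, nothing among the measured compounds tests an exchange of one five-membered aromatic ring for another on the core of compound 1. Among the compounds with values here, with no step to lean on, the expectation for compound 4 is a value within the scatter of compound 1, a 1.2-fold lower number from compound 1 to compound 4 (0.07 log units; within the scatter), with the range kept wide.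

Compound 4 is therefore estimated at 18 mL.min-1.g-1, between 6 mL.min-1.g-1 and 50 mL.min-1.g-1.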

Compound 4, intrinsic clearance in microsomes: 10 mL.min-1.g-1
Compound 4: middle estimate off by 1.8-fold (0.26 log units), on the high side, within the range that was stated.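

At this position, on an aromatic carbon of a six-membered aromatic ring with 1 nitrogen, the exchange of one five-membered aromatic ring for another gives a readable change in this assay: a 2.1-fold lower number from compound 1 to compound 4 (0.32 log units; beyond the scatter). For the compounds shown here, it is the first step in the set that can be sized, as the only earlier step, between compound 2 and compound 3 on a different core, cannot be read, both of its values being limits of the assay. The step also bundles two changes, since 1,2-dimethyl-1H-imidazol-5-yl differs from 3-(dimethylcarbamoyl)-1-methyl-1H-pyrazol-5-yl both in the ring itself and in the loss of the dimethylcarbamoyl group, and this one comparison does not separate them.

Nothing shown bears on the cause of this step. Still open, on these data alone, is whether the ring exchange or the loss of the dimethylcarbamoyl group carries the change, which a plain 1-methyl-1H-pyrazol-5-yl on the same core would address, and how a ring bearing a primary amine or a carboxylic acid would read at this position.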